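A few compounds are considered here, and "the series" means these few. Any claim that something is new, unique, unknown or untested is made for them only; others in the source may bear on it.

Measured values in an ADME assay on the whole organism (strain FVB) for pharmacokinetics, with Mus musculus as the target, read by LC-MS, at a dose of 30 mg/kg by the oral route (on this read-out lower numbers stand for lower exposure and higher numbers for higher exposure at the dose given), are as follows.

Compound 1 `c1cc([C@H]2CC[C@]3(CC2)OOC2(O3)C3CC4CC(C3)CC2C4)ccc1OCCOC1CCNCC1` gives 633 nM
Compound 2 `c1cc([C@H]2CC[C@]3(CC2)OOC2(O3)C3CC4CC(C3)CC2C4)ccc1OCCC1CCNCC1` gives 1190 nM
Compound 3 `c1cc([C@H]2CC[C@]3(CC2)OOC2(O3)C3CC4CC(C3)CC2C4)ccc1OC1CCNCC1` gives 810 nM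

These three compounds share one core and differ only in the group on an oxygen on an aromatic ring. Compound 3, at 810 nM, lies within the usual scatter of both other compounds, so the three cannot be ranked.

Compound 4 `O[C@H]1CC[C@H](NCCCOc2ccc([C@H]3CC[C@]4(CC3)OOC3(O4)C4CC5CC(C4)CC3C5)cc2)CC1` has 3-((4-hydroxycyclohexyl)amino)propyl in place of piperidin-4-yl at that same place. The counted difference is 3-((4-hydroxycyclohexyl)amino)propyl in place of piperidin-4-yl on an oxygen on an aromatic ring

Among the measured compounds shown here, three measured steps bear on this change, as each alters the group at this place: a 1.3-fold higher number from compound 1 to compound 3 (0.11 log units; within the scatter), a 1.5-fold lower number from compound 2 to compound 3 (0.17 log units; within the scatter), and a 1.9-fold higher number from compound 1 to compound 2 (0.27 log units; within the scatter). All three stay within the scatter. For the measured compounds named here, none of the measured compounds carries the hydroxycyclohexyl group, however, so the range has to stay wide.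

No step beyond the scatter is expected, and the estimated step is a 1.1-fold lower number from compound 3 to compound 4 (0.03 log units; within the scatter). For compound 4 the estimated value is 750 nM, with an expected range from 280 nM to 2000 nM.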

Compound 4, maximal plasma concentration: 721 nM
Beside the measured number, compound 4's estimate is 1.0-fold (0.02 log units) above it; the range from low to high includes it.
By their numbers in this assay, from the lowest: compounds 1, 4, 3 and 2 (each within the scatter of the next).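

Replacing piperidin-4-yl with 3-((4-hydroxycyclohexyl)amino)propyl in this assay moves the number only slightly (a 1.1-fold lower number from compound 3 to compound 4 (0.05 log units; within the scatter)). The comparisons with the other two compounds also stay small (a 1.7-fold lower number from compound 2 to compound 4 (0.22 log units; within the scatter); a 1.1-fold higher number from compound 1 to compound 4 (0.06 log units; within the scatter)). This shows that, among these four compounds, the group on an oxygen on an aromatic ring can change from a nitrogen-containing ring to a carbon-only ring with the nitrogen outside it, and gain a hydroxy group, without any step beyond the scatter. No measurement on hand explains this flat result.

Still open is whether the hydroxy group matters, as the same group without it, 3-(cyclohexylamino)propyl, is not among the compounds shown. Also open, on these data alone, is whether a group with no amine, such as a carboxylic acid on a propyl chain, would stay within the same narrow band.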